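Swapping a Silicon Group for a Decyl Chain

A few compounds are considered here, and "the series" means these few. Any claim that something is new, unique, unknown or untested is made for them only; others in the source may bear on it.

Of the compounds shown here, three have so far been tested in a functional assay on A549 cells (Homo sapiens) for antiproliferative activity, read by MTT assay, with a stated time of 72 h; a lower number here means a stronger inhibitor, a higher number a weaker inhibitor. Compound 1 `COc1ccc(-c2cn(C/C=C3\OC(=O)C(OCc4ccccc4)=C3OCc3ccccc3)nn2)cc1` gives only > 100000 nM, which is a limit of the assay rather than a number (the limit of > 100000 nM in this assay, at which 1 of the 3 values shown sits). Among the compounds with values here, compound 3 `O=C1O/C(=C\Cn2cc(-c3cccc(O)c3)nn2)C(OCc2ccccc2)=C1OCc1ccccc1` gives 23300 nM, and the change an at least 4.2-fold lower number from compound 1 to compound 3 (0.63 log units; beyond the scatter) is the only measured step here. Compound 2 `C[Si](C)(C)c1cn(C[C@H](O)[C@H]2OC(=O)C(OCc3ccccc3)=C2OCc2ccccc2)nn1` gives 19200 nM, the lowest of the two numbers, though compound 3 sits within the scatter of it.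

Compound 4 `CCCCCCCCCCc1cn(C[C@H](O)[C@H]2OC(=O)C(OCc3ccccc3)=C2OCc2ccccc2)nn1` differs from compound 2 by a group of 10 heavy atoms (10 carbon; no ring) in place of a group of 4 heavy atoms (3 carbon, 1 silicon; no ring), on an aromatic carbon. Within the data shown here, the one measured step concerns a different part of the shared core, so no measured step bears directly on this change, and there is no basis for expecting movement beyond the scatter in either direction. The step from compound 2 to compound 4 is therefore expected to be a 1.1-fold lower number from compound 2 to compound 4 (0.05 log units; within the scatter). In this assay compound 4 is estimated at 17000 nM, with a range from 5000 nM to 60000 nM.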

Compound 4, half-maximal inhibitory concentration: 6750 nM
For compound 4 the middle estimate is 2.5-fold (0.40 log units) above the measured one, within the range that was stated.
By their numbers in this assay, from the lowest: compound 4; then compounds 2 and 3 (each within the scatter of the next). At a limit, above all of these: compound 1.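

Within the data shown here, this is the first measured change at this aromatic carbon of the five-membered ring, and it shows that the position is not silent: in this assay, decyl in place of the silicon-bearing group gives a 2.8-fold lower number from compound 2 to compound 4 (0.45 log units; beyond the scatter), a modest step. Among these compounds, the earlier compounds could not show this, as their one measured step lies in a different part of the shared core. Nothing measured here explains the step.

Decyl differs from the departing group both in having no silicon and in its heavy-atom count, so this single pair cannot separate the two differences. The compounds shown also leave open whether a hexyl chain, a longer chain such as dodecyl, or a decyl chain ending in an amine or a carboxylic acid would lower the number further or raise it.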